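Removal of the pyrazole benzyl group in an amidine series

A few compounds are considered here, and "the series" means these few. Any claim that something is new, unique, unknown or untested is made for them only; others in the source may bear on it.

Three compounds of the shared core have numbers in a functional assay on MDA-MB-231 cells (Homo sapiens) for cytotoxicity, read by MTT assay, with a stated time of 72 h; a lower number here means a stronger inhibitor, a higher number a weaker inhibitor. Compound 1 `N=C(Nc1cccc(C(F)(F)F)c1)c1cc2c(-c3ccccc3)n[nH]c2cn1` gives 22300 nM. Compound 2 `N=C(Nc1ccccc1)c1cc2c(-c3ccccc3)n[nH]c2c(NC2CCCCC2)n1` gives 1710 nM. Compound 3 `COc1ccc(Cn2nc(-c3ccccc3)c3cc(C(=N)Nc4ccccc4)ncc32)cc1` gives 5400 nM, which places compound 3 second highest of the three, beyond the scatter from compound 2 on one side and from compound 1 on the other.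

The next compound is compound 4 `N=C(Nc1ccccc1)c1cc2c(-c3ccccc3)n[nH]c2cn1`, which is compound 3 with hydrogen in place of 4-methoxybenzyl on an aromatic nitrogen. Among the compounds with values here, no measured pair of the series isolates this change, so its effect can only be judged against the other two values: both compounds carrying the unsubstituted aromatic nitrogen sit on either side of compound 3, and the weaker of them, compound 1, lacks the amino substituent that compound 4 also lacks. The step is therefore expected to be modest and toward a higher number, with a fair chance of falling within the scatter, as a 1.7-fold higher number from compound 3 to compound 4 (0.22 log units; within the scatter). Compound 4 is estimated at 9000 nM, within a range from 2500 nM to 30000 nM.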

Compound 4, half-maximal inhibitory concentration: 11000 nM
Compound 4: middle estimate off by 1.2-fold (0.09 log units), on the low side; measured number inside the range.
By their numbers in this assay, from the lowest: compound 2; then compound 3; then compound 4; then compound 1.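

In this assay, a 2.0-fold higher number from compound 3 to compound 4 (0.31 log units; beyond the scatter) shows that the 4-methoxybenzyl group on this aromatic nitrogen can be replaced by hydrogen with a modest loss, and the cytotoxicity is not lost altogether. Compound 4 also links the two other compounds to the same hydrogen-bearing nitrogen: hydrogen in place of cyclohexylamino on an aromatic carbon corresponds to a 6.4-fold higher number from compound 2 to compound 4 (0.81 log units; beyond the scatter), while hydrogen in place of trifluoromethyl on an aromatic carbon corresponds to a 2.0-fold lower number from compound 1 to compound 4 (0.31 log units; beyond the scatter). Nothing measured here accounts for any of these steps.

Going by these compounds, it remains open whether a methyl or an unsubstituted benzyl group on this nitrogen would give a number closer to that of compound 3. Also open, on these data alone, is how morpholine or a shorter alkylamine would compare with cyclohexylamino on the aromatic carbon.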